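A few compounds are considered here, and "the series" means these few. Any claim that something is new, unique, unknown or untested is made for them only; others in the source may bear on it.

Measured in an assay on cell membranes for displacement of a labelled ligand from Neuronal acetylcholine receptor; alpha4/beta2 (Rattus norvegicus), read by radioligand binding, with a stated time of 30 min; a lower number here means a stronger inhibitor, a higher number a weaker inhibitor:

- compound 1 `OCc1cc(F)cc(C2=NCCCC2)c1`: 744 nM
- compound 2 `Fc1cccc(C2=NCCCC2)c1`: 2040 nM
- compound 3 `Brc1cc(Br)cc(C2=NCCCC2)c1`: 18800 nM

Compound 2 holds the second highest of the three numbers. Within the data shown here, the only single-site step among the measured compounds is a 2.7-fold higher number from compound 1 to compound 2 (0.44 log units; beyond the scatter), a modest weakening when hydrogen replaces hydroxymethyl. Among the measured compounds shown here, compound 3, with two bromines, gives a number well above that of compound 2, but no single step links the two.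

Compound 4 `Clc1cccc(C2=NCCCC2)c1` differs from compound 2 by chloro in place of fluoro on an aromatic carbon. For the measured compounds named here, no measured step bears on a halogen swap of this kind, so the data give no direction. Compound 4 is therefore expected to change little beyond the scatter in this assay, with a 1.2-fold higher number from compound 2 to compound 4 (0.09 log units; within the scatter), and its estimated value is 2500 nM, between 1000 nM and 6500 nM.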

Compound 4, inhibition constant: 11500 nM
Compound 4: the middle estimate sits 4.6-fold (0.66 log units) below what was measured; the whole stated range lies below it.
By their numbers in this assay, from the lowest: compound 1; then compound 2; then compounds 4 and 3 (each within the scatter of the next).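

In this assay this position on the aromatic ring proves sensitive to the identity of the halogen, with chloro in place of fluoro giving a 5.6-fold higher number from compound 2 to compound 4 (0.75 log units; beyond the scatter). Fluoro and chloro each count one heavy atom and neither carries a hydrogen-bond donor or acceptor, yet the step lies beyond the scatter. Nothing measured here accounts for this step.

As far as these compounds go, whether a methoxy group, a nitrile or an amine at this position would stay nearer to compound 2 or to compound 4 remains open. So does whether adding hydroxymethyl to compound 4 would lower its number as it does for the fluoro compounds.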